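Swapping bromo for fluoro on an aromatic carbon

The source may hold more compounds than are shown below. What is called first, only, known or untested is meant among the compounds shown, and "the series" means these compounds.

Measured in an ADME assay on Vero cells (Chlorocebus sabaeus) for cytotoxicity, read by resazurin assay, with a stated time of 72 h; a higher number here means a weaker inhibitor, a lower number a stronger inhibitor:
- compound 1 `O=C(CCN1CCN(c2ccc(C(F)(F)F)cc2)CC1)c1ccccc1`: 15700 nM
- compound 2 `O=C(CCN1CCN(c2ccc(C(F)(F)F)cc2)CC1)c1ccc(Br)cc1`: 78800 nM
- compound 3 `O=C(CCN1CCN(c2ccc(C(F)(F)F)cc2)CC1)c1ccc(F)c(Br)c1`: 66800 nM

The two bromo compounds cannot be told apart, with a 1.2-fold lower number from compound 2 to compound 3 (0.07 log units; within the scatter). Compound 3 still stands clear of the bromo-free parent, with a 4.3-fold higher number from compound 1 to compound 3 (0.63 log units; beyond the scatter). Compound 4 `O=C(CCN1CCN(c2ccc(C(F)(F)F)cc2)CC1)c1ccc(F)c(F)c1` follows from compound 3 by fluoro in place of bromo on an aromatic carbon. Among the measured compounds shown here, no measured step makes this exact swap. The nearest guide is the addition of bromo, with a 5.0-fold higher number from compound 1 to compound 2 (0.70 log units; beyond the scatter), so part of that rise may be lost when bromo leaves. The expected change is a 1.8-fold lower number from compound 3 to compound 4 (0.24 log units; within the scatter), towards a lower number in this assay. The estimate for compound 4 is 38000 nM, with an expected range of 15000 nM to 85000 nM.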

Compound 4, half-maximal inhibitory concentration: 14000 nM
Compound 4: middle estimate off by 2.7-fold (0.43 log units), on the high side, outside the stated range (below it).
By their numbers in this assay, from the lowest: compounds 4 and 1 (each within the scatter of the next); then compounds 3 and 2 (each within the scatter of the next).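

In this assay, the higher number at this position goes with bromo itself, not with the ring carrying a second halogen: exchanging it for fluoro gives a clear drop (a 4.8-fold lower number from compound 3 to compound 4 (0.68 log units; beyond the scatter)). The difluoro compound also stands well apart from the 4-bromophenyl compound (a 5.6-fold lower number from compound 2 to compound 4 (0.75 log units; beyond the scatter)), yet cannot be told apart from the unsubstituted phenyl parent (a 1.1-fold lower number from compound 1 to compound 4 (0.05 log units; within the scatter)). So on this ring, fluoro does not reproduce the rise seen with bromo, and nothing available explains the difference. Going by these compounds, whether chloro or methyl at this position would behave like bromo or like fluoro remains open.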